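Thiocarbonyl replaced by ester on the thioether sulfur

The compounds below may be only part of what the source reports. "The series", "measured", "known", "first", "only" and "open" are said of these compounds alone.

Measured so far:
compound 1 `CCNC(=S)SCC(=O)c1ccc(OC)cc1` 94 nM
compound 2 `CCSC(=S)SCC(=O)c1cccc(S(=O)(=O)N(C)c2ccc(OC)cc2)c1` 2040 nM
compound 3 `CCSC(=S)SCC(=O)c1ccc(C(=O)NCc2ccccc2)cc1` 830 nM

In an assay on HEK293 cells for inhibition of protein deacetylase HDAC6 (Homo sapiens) (on this read-out lower numbers stand for stronger inhibition and higher numbers for weaker inhibition), compound 1 gives the lowest number of the three, and the gaps to compound 3 and to compound 2 both lie beyond the usual scatter. Among the compounds with values here, no pair among the measured compounds differs in a single place, so no step has been measured directly. Compound 4 `CCOC(=O)SCC(=O)c1ccc(OC)cc1` is not yet measured. It differs from compound 1 as follows: a group of 5 heavy atoms (3 carbon, 2 oxygen; no ring) in place of a group of 5 heavy atoms (3 carbon, 1 nitrogen, 1 sulfur; no ring), on a sulfur. Within the data shown here, since no measured pair shows this kind of change, the expectation rests on compound 1 alone, and the step from compound 1 to compound 4 is expected to be a clear loss: a 5.3-fold higher number from compound 1 to compound 4 (0.73 log units; beyond the scatter). Compound 4 is estimated at 500 nM in this assay, with a range from 150 nM to 2000 nM.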

Compound 4, half-maximal inhibitory concentration: 5360 nM
Compound 4: middle estimate off by 11-fold (1.03 log units), on the low side; measured number outside the range, above it.
By their numbers in this assay, from the lowest: compound 1; then compound 3; then compound 2; then compound 4.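

At this sulfur, this assay records a 57-fold higher number from compound 1 to compound 4 (1.76 log units; beyond the scatter) when ethoxycarbonyl enters, a large step beyond the scatter and the first direct measure of any change here. So the position is far from indifferent to this exchange, even though the group keeps the same count of heavy atoms and one double bond. The exchange alters the nitrogen and the sulfur together, and nothing available explains the loss. An ethylaminocarbonyl group on the core of compound 1, keeping the nitrogen with oxygen replacing the sulfur, would help separate the two changes.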